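Trading chloro for cyano on compound 1

The source may hold more compounds than are shown below. What is called first, only, known or untested is meant among the compounds shown, and "the series" means these compounds.

Compound 1 `N#Cc1cc(Cl)ccc1NC(=O)c1ccc2cccnc2c1O` gives 790 nM
Compound 2 `O=C(Nc1ccc(Cl)cc1Cl)c1ccc2cccnc2c1O` gives 610 nM
Compound 3 `O=C(Nc1ccc(Cl)cc1)c1ccc2cccnc2c1O` gives 630 nM

These three values come from a functional assay on HL-60 cells (Homo sapiens) for cytotoxicity, read by luminescence and CellTiter-Glo, with a stated time of 3 days (on this read-out higher numbers stand for weaker inhibition and lower numbers for stronger inhibition), and lie within the scatter of one another, so compound 1 stands level with the other two. Compound 4 `N#Cc1ccc(NC(=O)c2ccc3cccnc3c2O)c(C#N)c1` has not yet been measured. It differs from compound 1 at one place, with cyano in place of chloro on an aromatic carbon, para to a large group and meta to a cyano group (cyano in place of chloro on an aromatic carbon). Within the data shown here, all three measured compounds keep chloro on that carbon, so no measured step tests this change directly. The nearest evidence is indirect. The same two groups exchanged on a different aromatic carbon gave a 1.3-fold lower number from compound 1 to compound 2 (0.11 log units; within the scatter) and hydrogen on that carbon gave a 1.3-fold lower number from compound 1 to compound 3 (0.10 log units; within the scatter) and a 1.0-fold higher number from compound 2 to compound 3 (0.01 log units; within the scatter) in turn. On the strength of these small steps, no shift beyond the scatter is expected. The estimated change is a 1.0-fold higher number from compound 1 to compound 4 (0.01 log units; within the scatter) in this assay and this remains an expectation until a measurement exists. Compound 4 is expected at 800 nM with an estimated range from 350 nM to 1800 nM in this assay when tested.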

Compound 4, half-maximal inhibitory concentration: 890 nM
Beside the measured number, compound 4's estimate is 1.1-fold (0.05 log units) below it; the range from low to high includes it.
By their numbers in this assay, from the lowest: compounds 2, 3, 1 and 4 (each within the scatter of the next).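

Compound 4 gives the first direct test of this carbon, which is para to a large group and meta to a cyano group, and cyano in place of chloro there gives a 1.1-fold higher number from compound 1 to compound 4 (0.05 log units; within the scatter) in this assay. The result therefore shows that, with the other cyano group held in place, this carbon can carry either chloro or cyano, the entering group having two heavy atoms where the leaving group has one, without a step beyond the scatter. No other data shown here bear on this result, so the compounds offer no account of why the step is this small.

With only chloro and cyano shown on this carbon, it remains open whether hydrogen, an amine, a carboxylic acid or a longer chain there would also stay within the scatter of compound 1 or would bring a larger step. As far as these compounds go, it also remains open whether cyano on this carbon would give a similarly small step if the neighbouring substituent on the ring were chloro or hydrogen rather than cyano.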